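A few compounds are considered here, and "the series" means these few. Any claim that something is new, unique, unknown or untested is made for them only; others in the source may bear on it.

In a functional assay on the whole organism (strain Swiss albino) with Mus musculus as the target, with a stated time of 0.5 h (a higher number here means that more compound is needed for the effect, a lower number that less compound is needed), the two measured compounds gave:
Compound 1 `O=C(/N=C/c1ccccc1Cl)Nc1ccc2c(c1)C(=O)C(=O)N2CN1CCCCC1`: 300 mg/kg
Compound 2 `O=C(/N=C/c1ccc(F)cc1)Nc1ccc2c(c1)C(=O)C(=O)N2CN1CCCCC1`: 100 mg/kg

Among the compounds with values here, compound 2 has the lower of the two numbers; the single measured step is a 3.0-fold lower number from compound 1 to compound 2 (0.48 log units; beyond the scatter), and it lies beyond the scatter. Compound 3 `O=C(/N=C/c1ccc([N+](=O)[O-])cc1)Nc1ccc2c(c1)C(=O)C(=O)N2CN1CCCCC1` differs from compound 2 by nitro in place of fluoro on an aromatic carbon. Within the data shown here, no measured step exchanges a fluoro for a nitro, so that one step concerns a different change and gives no direct guide here. The expectation for compound 3 in this assay is therefore no step beyond the scatter, no change at the digits printed from compound 2 to compound 3 (within the scatter). For compound 3 the estimate is 100 mg/kg, with a range from 50 mg/kg to 300 mg/kg.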

Compound 3, minimum effective dose: 300 mg/kg
Compound 3: middle estimate off by 3.0-fold (0.48 log units), on the low side, and the stated range covers the measured number.
By their numbers in this assay, from the lowest: compound 2; then compounds 1 and 3 (each within the scatter of the next).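

In this assay nitro in place of fluoro on an aromatic carbon brings a 3.0-fold higher number from compound 2 to compound 3 (0.48 log units; beyond the scatter) and so shows that, with the position held fixed, the group placed there alters the dose needed. The exchange of 2-chlorophenyl for 4-nitrophenyl brings no change at the digits printed from compound 1 to compound 3 (within the scatter) and leaves compound 2 alone apart from the other two. Nothing measured here accounts for this difference. On these data alone, whether an amine or a methoxy group on the same aromatic carbon would match compound 2 or compound 3 stays open.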